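Trading 2-methylbenzyl for 3-fluorobenzyl on a shared core

The compounds below may be only part of what the source reports. "The series", "measured", "known", "first", "only" and "open" are said of these compounds alone.

In a functional assay on HCT-116 cells (Homo sapiens) for antiproliferative activity, read by MTT assay, with a stated time of 24 h (a lower number here means a stronger inhibitor, a higher number a weaker inhibitor), compound 1 (`COc1cc(OC)c(-c2coc3cc(OCC(=O)c4cccc(C(F)(F)F)c4)ccc3c2=O)cc1OC`) reaches only a limit of the assay, > 10000 nM. Compound 2 (`COc1cc(OC)c(-c2coc3cc(OCc4ccc(F)cc4)ccc3c2=O)cc1OC`) gives 950 nM. Compound 3 (`COc1cc(OC)c(-c2coc3cc(OCc4ccccc4C)ccc3c2=O)cc1OC`) gives 2900 nM, the higher of the two actual numbers, with compound 2 nearest. Compound 4 (`COc1cc(OC)c(-c2coc3cc(OCc4cccc(F)c4)ccc3c2=O)cc1OC`) carries 3-fluorophenyl in place of 2-methylphenyl on a saturated chain carbon bound to an oxygen on an aromatic ring. The closest guide is a 3.1-fold higher number from compound 2 to compound 3 (0.48 log units; beyond the scatter), where 2-methylphenyl replaced 4-fluorophenyl. For the measured compounds named here, a modest move back toward compound 2 at 950 nM is therefore expected in this assay, although no 3-fluorophenyl compound has been measured. The expected step is a 2.1-fold lower number from compound 3 to compound 4 (0.32 log units; beyond the scatter). For compound 4 the estimated value is 1400 nM, within a range of 500 nM to 4000 nM.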

Compound 4, half-maximal inhibitory concentration: 4920 nM
The estimate for compound 4 lay 3.5-fold (0.55 log units) below the measured number; measured number above the stated range.
By their numbers in this assay, from the lowest: compound 2; then compounds 3 and 4 (each within the scatter of the next). At a limit, above all of these: compound 1.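

In this assay the swap of 2-methylphenyl for 3-fluorophenyl on this saturated chain carbon leaves the number within the scatter (a 1.7-fold higher number from compound 3 to compound 4 (0.23 log units; within the scatter)). For the compounds shown here, the earlier compounds held only one fluorophenyl group; compound 4 shows that the two fluorophenyl groups are not interchangeable here (a 5.2-fold higher number from compound 2 to compound 4 (0.71 log units; beyond the scatter)). Against compound 1 only a floor can be read (an at least 2.0-fold lower number from compound 1 to compound 4 (0.30 log units; that floor lies within the scatter)), since the value of compound 1 is a limit: the limit of > 10000 nM in this assay, at which 1 of the 4 values shown sits. On these data alone, whether 2-fluorophenyl or 4-methylphenyl would fall nearer compound 2 or compound 3 stays open.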